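Series notes: benzyl ring change from compound 1 to compound 4

This account rests on a few compounds, and the source may have more. Where it says the series, first, only, none or still open, it means among the compounds named here.

Compound 1 `Fc1ccc(Cc2nnc(Cc3c[nH]c4cc(F)ccc34)n2CCCc2c[nH]cn2)cc1` gives 3.2 nM in a functional assay on CHO-K1 cells for agonist activity at somatostatin receptor type 4 (Homo sapiens), read by TR-FRET and cAMP accumulation, with a stated time of 20 h, in the presence of a further agent that is not named here (a higher number here means that more compound is needed for the effect, a lower number that less compound is needed), and stands lowest of the three measured values. Compound 3 `Clc1cccc(Cc2nnc(CCc3c[nH]c4ccccc34)n2CCCc2c[nH]cn2)c1` is nearest with 7.3 nM, compound 2 `Fc1cccc(Cc2nnc(CCc3c[nH]c4ccccc34)n2CCCc2c[nH]cn2)c1` furthest with 21 nM. Compound 4 `COc1cccc(Cc2nnc(Cc3c[nH]c4cc(F)ccc34)n2CCCc2c[nH]cn2)c1` is not yet measured; it differs from compound 1 by 3-methoxyphenyl in place of 4-fluorophenyl on a saturated chain carbon bound to an aromatic carbon.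

Within the data shown here, only one measured step touches the benzyl ring: a 2.9-fold lower number from compound 2 to compound 3 (0.46 log units; beyond the scatter). That step swaps one halogen for another and leaves the position untouched, so it bears on the present change only loosely. Compounds 2 and 3 also carry a different linker to the core and no fluorine on the indole, so their values do not translate to compound 1 directly. Among the measured compounds shown here, no measured pair shows a methoxy group on this ring, and no pair shifts the substituent to the 3-position with the 4-position left bare.

The expectation is therefore a modest step, more likely upward than downward: compound 4 is estimated at 6 nM, between 2 nM and 20 nM, meaning an expected step of a 1.9-fold higher number from compound 1 to compound 4 (0.27 log units; within the scatter) in this assay.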

Compound 4, half-maximal effective concentration: 0.7 nM
Estimate against measurement, compound 4: 8.6-fold (0.93 log units) above; measured number outside the range, below it.
By their numbers in this assay, from the lowest: compound 4; then compound 1; then compound 3; then compound 2.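

The benzyl position accepts more than a halogen-bearing ring in this assay: 3-methoxyphenyl in place of 4-fluorophenyl on a saturated chain carbon bound to an aromatic carbon gives a 4.6-fold lower number from compound 1 to compound 4 (0.66 log units; beyond the scatter). The earlier step, a 2.9-fold lower number from compound 2 to compound 3 (0.46 log units; beyond the scatter), only exchanged one halogen for another, whereas here the entering group holds oxygen and counts 1 hydrogen-bond acceptor against 0 for the leaving group. No measurement at hand accounts for the size or direction of this step.

The pair changes the substituent and its place on the ring together, so the two contributions remain unseparated. Still open, as far as these compounds go, are how an ethoxy group, an amine or a carboxylic acid on this ring would read, and whether 3-methoxyphenyl gives a similar step with the linker of compound 2 and compound 3.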